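Swapping Difluoromethyl for Cyano: an Expected Half-Life

The source may hold more compounds than are shown below. What is called first, only, known or untested is meant among the compounds shown, and "the series" means these compounds.

Of the compounds shown here, three built on one shared core have been measured in an ADME assay on microsomes from liver (Mus musculus) for metabolic stability; on this read-out lower numbers stand for a shorter-lived compound and higher numbers for a longer-lived compound. Compound 1 `NS(=O)(=O)CC(=O)NCCSc1nonc1/C(=N/O)Nc1cccc(C(F)F)c1` carries a difluoromethyl group on an aromatic carbon; in this assay compound 1 gives 1.5 h, the highest of the three numbers, although the nearest neighbour, compound 2, sits within the scatter of it. Compound 2 `NS(=O)(=O)CC(=O)NCCSc1nonc1/C(=N/O)Nc1cccc(Cl)c1` has chloro in that position and gives 1.26 h. Compound 3 `NS(=O)(=O)CC(=O)NCCSc1nonc1/C(=N/O)Nc1cccc(Br)c1` has bromo there and gives 0.918 h. The step of a 1.2-fold lower number from compound 1 to compound 2 (0.08 log units; within the scatter) and the step of a 1.6-fold lower number from compound 1 to compound 3 (0.21 log units; within the scatter) both lie inside the scatter, as does a 1.4-fold lower number from compound 2 to compound 3 (0.14 log units; within the scatter); exchanging the difluoromethyl for a halogen has not moved the half-life in a way that can be relied on.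

Compound 4 `N#Cc1cccc(N/C(=N\O)c2nonc2SCCNC(=O)CS(N)(=O)=O)c1` is the unmeasured partner of compound 1. The change is cyano in place of difluoromethyl on an aromatic carbon. For the measured compounds named here, no measured step exchanges difluoromethyl for cyano, so the two halogen steps from compound 1 are the closest guide, and each was small. On that basis a step of similar size is expected, a 1.2-fold lower number from compound 1 to compound 4 (0.06 log units; within the scatter), leaning slightly downward but quite possibly none beyond the scatter. Compound 4 is therefore estimated at 1.3 h, within a range from 0.7 h to 2.4 h.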

Compound 4, half-life: > 3 h
Compound 4: a limit, no number (the forecaster's own chance of this, stated with the estimate: 2%); middle value at least 2.3-fold (0.36 log units) away from the limit.
By their numbers in this assay, from the lowest: compounds 3, 2 and 1 (each within the scatter of the next). At a limit, above all of these: compound 4.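

At this position on the shared core, the earlier exchanges among difluoromethyl, chloro and bromo all stayed inside the scatter, so the position had shown no reliable response. Cyano is the first group here to clear the scatter in this assay, with an at least 3.2-fold higher number from compound 3 to compound 4 (0.51 log units; beyond the scatter) and an at least 2.3-fold higher number from compound 2 to compound 4 (0.37 log units; beyond the scatter); against the two halogens, this change does matter. The comparison with difluoromethyl is less firm, with an at least 2.0-fold higher number from compound 1 to compound 4 (0.30 log units; that floor lies within the scatter), so that step alone does not set cyano apart from the group it replaced, and because the result for compound 4 is a limit of the assay and not a number, all three steps give only floors: the limit of > 3 h in this assay, at which 1 of the 4 values shown sits.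

Going by these compounds, it remains open whether this standing belongs to the nitrile alone or would also be reached by other groups on this aromatic carbon, such as trifluoromethyl, methoxy or a primary amide. The compounds shown also leave open whether cyano would keep its standing if another part of the shared core were changed.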